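From 4-cyanophenyl to 4-methylphenyl in the series

A few compounds are considered here, and "the series" means these few. Any claim that something is new, unique, unknown or untested is made for them only; others in the source may bear on it.

In an ADME assay (liver) for metabolic stability, with Liver microsome (Homo sapiens) as the target, using microsomes (a higher number here means that the compound lasts longer, a lower number that the compound disappears faster), compound 1 `CCCc1nc2ccccn2c1C(=O)NCc1ccc(-c2ccccc2)cc1` gives 0.373 h. Compound 2 `CCc1nc2ccc(Cl)cn2c1C(=O)NCc1ccc(-c2ccccc2Cl)cc1` gives 0.648 h. Compound 3 `CCc1nc2ccc(Cl)cn2c1C(=O)NCc1ccc(-c2ccc(C#N)cc2)cc1` gives > 2 h in this assay, which is a limit and not a number. Its place is the limit of > 2 h in this assay, at which 1 of the 3 values shown sits.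

Compound 4 `CCc1nc2ccc(Cl)cn2c1C(=O)NCc1ccc(-c2ccc(C)cc2)cc1` carries methyl in place of cyano on an aromatic carbon, methyl in place of cyano on an aromatic carbon, para to a large group. Within the data shown here, the one measured step that bears on this change is an at least 3.0-fold higher number from compound 2 to compound 3 (0.48 log units; beyond the scatter). That step brought the 4-cyanophenyl in, so losing the cyano is expected to give back much of the gain in this assay. The expected step, a lower number beyond the scatter, is an at least 2.5-fold lower number from compound 3 to compound 4 (0.39 log units; beyond the scatter). For compound 4 the estimate is 0.8 h, with an expected range of 0.35 h to 1.8 h.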

Compound 4, half-life in the Liver microsome assay: 0.508 h
Beside the measured number, compound 4's estimate is 1.6-fold (0.20 log units) above it; the measured number falls inside the stated range.
By their numbers in the Liver microsome assay, from the lowest: compounds 1, 4 and 2 (each within the scatter of the next). At a limit, above all of these: compound 3.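

At this place, para to a large group, the cyano matters in the Liver microsome assay: there is an at least 3.9-fold lower number from compound 3 to compound 4 (0.59 log units; beyond the scatter), and compound 4 gives 0.508 h. In the Liver microsome assay compound 3 gives > 2 h, which is a limit and not a number, so the size of this step is only a bound. For 4-methylphenyl in place of 2-chlorophenyl, 4-methylphenyl and 2-chlorophenyl stand level in the Liver microsome assay with a 1.3-fold lower number from compound 2 to compound 4 (0.11 log units; within the scatter).

Still open, going by these compounds, is whether an amine or a carboxylic acid at this place would keep the half-life of compound 3 and also raise the number in a physicochemical assay for solubility, in phosphate buffer, at pH 7.4 (on this read-out lower numbers stand for lower solubility and higher numbers for higher solubility), where the cyano-to-methyl change gives a 2.6-fold higher number from compound 3 to compound 4 (0.41 log units; beyond the scatter). In the physicochemical assay compound 3 gives 0.61 ug/mL and compound 4 gives 1.56 ug/mL.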